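The source may report more compounds than this note shows. Statements on the series, on what has been measured and on what is new or still open speak of the compounds shown alone.

Measured so far:
Compound 1 `CCCCCCCCCCc1ccc(-c2noc(C(Cl)CCN)n2)cc1` — in an assay on HeLa cells for inhibition of sphingosine-1-phosphate transporter SPNS2 (Mus musculus), read by LC-MS, tested at 2 uM (a lower number here means less inhibition, a higher number more inhibition at the concentration tested (going by the name of the read-out)), compound 1 gives 5%.
Compound 2 `CCCCCCCCCCc1ccc(-c2noc(CC(O)CN)n2)cc1` — in this assay compound 2 gives 59%.
Compound 3 `CCCCCCCCCCc1ccc(-c2noc(CCCN3CCCCC3)n2)cc1` — in this assay compound 3 gives 0%.

Compound 3 has the lowest of the three numbers. Compound 1 sits close to it, the step being a number 5 percentage points lower from compound 1 to compound 3 (within the scatter), while compound 2 stands well above it, the step being a number 59 percentage points lower from compound 2 to compound 3 (beyond the scatter).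

Compound 4 `CCCCCCCCCCc1ccc(-c2noc(CC(O)CN(C)C)n2)cc1` differs from compound 3 in one place: 2-(dimethylamino)-1-hydroxyethyl in place of 2-(piperidin-1-yl)ethyl on a saturated chain carbon bound to an aromatic carbon. This change brings back the hydroxyl group and a nitrogen on a short chain, much as in compound 2, so the step from compound 2 to compound 3 bears on it directly, and it was large. The step of a number 54 percentage points higher from compound 1 to compound 2 (beyond the scatter) also points the same way, the hydroxyl-bearing chain scoring far higher than the chlorine-bearing one. What the measured compounds do not show is the effect of the two methyl groups on the nitrogen in compound 4 in place of the hydrogens in compound 2, so the expected rise is tempered.

A clear rise is therefore expected, roughly a number 38 percentage points higher from compound 3 to compound 4 (beyond the scatter). For compound 4 the estimate in this assay is 38%, expected to fall between 12% and 65%.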

Compound 4, a percentage reported as inhibition, at one concentration (the size of the read-out at that concentration, not a potency): 61%
The estimate for compound 4 lay 23 percentage points below the measured number; low and high end bracket the measured number.
By their numbers in this assay, from the lowest: compounds 3 and 1 (each within the scatter of the next); then compounds 2 and 4 (each within the scatter of the next).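

Two methyl groups on the nitrogen of this hydroxyl-bearing chain make no readable difference in this assay, with a number 2 percentage points higher from compound 2 to compound 4 (within the scatter), so compound 4 scores on a par with compound 2. A nitrogen without hydrogens therefore does not by itself give a low number, since a number 61 percentage points higher from compound 3 to compound 4 (beyond the scatter) and a number 56 percentage points higher from compound 1 to compound 4 (beyond the scatter) are both large steps. No measurement shown here accounts for these steps.

The step from compound 3 to compound 4 swaps the piperidine ring for dimethylamino and adds the hydroxyl in one move, so the two changes cannot be told apart, and a 3-(dimethylamino)propyl chain without the hydroxyl would separate them. Also open, as far as these compounds go, is how a pyrrolidine or morpholine ring on the hydroxyl-bearing chain, or a carboxylic acid in place of the amine, would score.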